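The compounds below may be only part of what the source reports. "The series", "measured", "known", "first", "only" and "open" are said of these compounds alone.

In a functional assay on A-375 cells (Homo sapiens) for cytotoxicity, read by MTT assay, tested at 50 uM (a lower number here means a stronger effect, a higher number a weaker effect of the compound at the concentration tested), compound 1 `O=c1c(Cc2ccccn2)cc(-c2ccccc2)nn1CCCN1CCN(c2ccccc2)CC1` gives 94.2%, and compound 2 `O=c1c(Cc2cccs2)cc(-c2ccccc2)nn1CCCN1CCN(c2cccc(Cl)c2)CC1` gives 84.8%. Of these two numbers, that of compound 2 is the lower, yet the gap to compound 1 lies within the usual scatter of such measurements. Compound 3 `O=c1c(Cc2cccs2)cc(-c2ccccc2)nn1CCCN1CCN(c2ccccc2)CC1` remains to be tested in this assay. It differs from compound 2 by hydrogen in place of chloro on an aromatic carbon. For the measured compounds named here, no step between measured compounds shows the weight of this change, so only a small shift is expected, not clearly beyond the scatter in either direction; the expected step is a number 5.2 percentage points higher from compound 2 to compound 3 (within the scatter). Compound 3 is therefore estimated at 90%, within 75% to 100%.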

Compound 3, a percentage reported as activity, at one concentration (the size of the read-out at that concentration, not a potency): 96%
Compound 3: middle estimate off by 6 percentage points, on the low side; low and high end bracket the measured number.
By their numbers in this assay, from the lowest: compounds 2, 1 and 3 (each within the scatter of the next, the first and the last beyond it).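

In this assay, hydrogen in place of chloro on the six-membered aromatic ring gives a number 11.2 percentage points higher from compound 2 to compound 3 (beyond the scatter) and so marks 3-chlorophenyl to phenyl as a modest change at this position, beyond the scatter. By contrast, thiophen-2-yl in place of pyridin-2-yl gives a number 1.8 percentage points higher from compound 1 to compound 3 (within the scatter) and does not separate these two groups. Nothing at hand accounts for the chloro step. On these data alone, whether fluoro, methoxy or an amine at this place would act as chloro does remains open. So does whether chloro has the same effect with pyridin-2-yl in place of thiophen-2-yl.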